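Ester and aryl changes on the dihydropyridinone core

The source may report more compounds than this note shows. Statements on the series, on what has been measured and on what is new or still open speak of the compounds shown alone.

Working notes on the series. Compound 1 `CC1=C(C(=O)OCc2ccc(C(C)(C)C)cc2)C(c2cccc(Br)c2)C2=C(CC(C)(C)CC2=O)N1` in an assay on HEK293 cells for inhibition of neurogenic locus notch homolog protein 1 (Homo sapiens), read by a luciferase reporter and resazurin assay, with a stated time of 16 h (on this read-out higher numbers stand for weaker inhibition and lower numbers for stronger inhibition), gives 4270 nM. Compound 2 `CC1=C(C(=O)O[C@H](CC#N)c2ccccc2)C(c2cccc(Br)c2)C2=C(CC(C)(C)CC2=O)N1` in this assay gives only a limit, > 10000 nM. Within the data shown here, the one step measured in one place is an at least 2.3-fold higher number from compound 1 to compound 2 (0.36 log units; beyond the scatter), a change on the ester oxygen, not on the aryl ring. Compound 3 `CC1=C(C(=O)OCC2CCN(C(=O)OC(C)(C)C)CC2)C(c2cccc([N+](=O)[O-])c2)C2=C(CC(C)(C)CC2=O)N1` in this assay likewise gives only a limit, > 10000 nM; it therefore stands at the weak end of the numbers shown, shared with the limit of > 10000 nM in this assay, at which 2 of the 3 values shown sit. Compound 4 `CC1=C(C(=O)OCC2CCN(C(=O)OC(C)(C)C)CC2)C(c2ccc3ccccc3n2)C2=C(CC(C)(C)CC2=O)N1` differs from compound 3 by quinolin-2-yl in place of 3-nitrophenyl on a saturated ring carbon. No measured step touches this aryl position, so nothing shown gives the size or direction of the change in this assay; the ester step from compound 1 to compound 2 is at a different place and cannot be carried over. With compound 3 already at the limit, compound 4 is estimated at 8000 nM (range 2000 nM to 30000 nM), which means an expected step of an at least 1.2-fold lower number from compound 3 to compound 4 (0.09 log units; that floor lies within the scatter), with a real chance that only a limit is again reported.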

Compound 4, half-maximal inhibitory concentration: 330 nM
Beside the measured number, compound 4's estimate is 24-fold (1.38 log units) above it, and the stated range ends above it.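

In this assay, among these compounds, the aryl group on the saturated ring carbon proves to be a strong lever: with the ester unchanged, quinolin-2-yl in place of 3-nitrophenyl gives an at least 30-fold lower number from compound 3 to compound 4 (1.48 log units; beyond the scatter), the first measured step at this position. The ester shared by this pair therefore does not by itself hold a compound at the weak end of the series. The step is a floor rather than a full size, because compound 3 carries only a limit: the limit of > 10000 nM in this assay, at which 2 of the 4 values shown sit.

Which part of quinolin-2-yl carries the change stays open: a pyridin-2-yl or a naphthalen-2-yl group in the same place would separate the ring nitrogen from the second aromatic ring. Also open, going by these compounds, is whether quinolin-2-yl gives a similar step when paired with the ester of compound 1.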